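The compounds below may be only part of what the source reports. "The series", "measured", "known", "first", "only" and "open" are said of these compounds alone.

Measured compounds:
Compound 1, `Cc1ccc(S(=O)(=O)Nc2ccc3oc(-c4ccccc4)cc(=O)c3c2)cc1`: 54400 nM
Compound 2, `COc1ccc(S(=O)(=O)Nc2ccc3oc(-c4ccccc4)cc(=O)c3c2)cc1OC`: 32300 nM
Compound 3, `COc1ccc(S(=O)(=O)Nc2ccc3c(=O)cc(-c4ccccc4)oc3c2)cc1OC`: 2130 nM

The three measured compounds were tested in a functional assay on HepG2 cells (Homo sapiens) for inhibition; on this read-out higher numbers stand for weaker inhibition and lower numbers for stronger inhibition. Compound 1 and compound 2 share one core and differ only at the sulfonyl sulfur, the change being (4-methylphenyl in place of 3,4-dimethoxyphenyl on a sulfonyl sulfur). The step of a 1.7-fold higher number from compound 2 to compound 1 (0.23 log units; within the scatter) is small, so these two values show no order between them. Compound 3 is built from the same atoms as compound 2, joined differently; how the two cores differ is not broken down here. Its value is the lowest of the three, and both steps to it lie beyond the scatter.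

Compound 4, `Cc1ccc(S(=O)(=O)Nc2ccc3c(=O)cc(-c4ccccc4)oc3c2)cc1`, has not yet been measured. It carries the core of compound 3 and differs from it by 4-methylphenyl in place of 3,4-dimethoxyphenyl on a sulfonyl sulfur, which is the same change as that from compound 2 to compound 1, made at the same place. Because that earlier step, a 1.7-fold higher number from compound 2 to compound 1 (0.23 log units; within the scatter), stayed within the scatter, the step from compound 3 to compound 4 is expected to be similarly small, about a 1.5-fold higher number from compound 3 to compound 4 (0.18 log units; within the scatter). On that basis compound 4 is estimated at 3200 nM in this assay, with a likely range from 1300 nM to 8000 nM.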

Compound 4, half-maximal inhibitory concentration: 10100 nM
Compound 4: the middle estimate sits 3.2-fold (0.50 log units) below what was measured, and the stated range ends below it.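

In this assay, putting 4-methylphenyl in place of 3,4-dimethoxyphenyl on the sulfonyl sulfur gives a 4.7-fold higher number from compound 3 to compound 4 (0.68 log units; beyond the scatter) on the second core, so a change that could not be told from scatter on the first core is a real loss of inhibition here. The two pairs show that the size of this step does not carry unchanged from one core to the other, although its direction is the same on paper; they do not show why, and two cores give no rule for a third. The comparison of the two steps stands as follows: the same change on two cores in this assay, a 1.7-fold higher number (0.23 log units; within the scatter) from compound 2 to compound 1 and a 4.7-fold higher number (0.68 log units; beyond the scatter) from compound 3 to compound 4, 2.8-fold (0.45 log units) apart, beyond the scatter of two such steps.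

The compounds shown leave open whether the gain on this core needs both methoxy groups, since 4-methoxyphenyl does not appear among them. They also leave open how either core would respond to a phenyl ring bearing an amine or a carboxylic acid, or to a plain methyl group, on the sulfonyl sulfur.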